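This account rests on a few compounds, and the source may have more. Where it says the series, first, only, none or still open, it means among the compounds named here.

Working notes on the series, all read in a functional assay on MCF7 cells (Homo sapiens) for cytotoxicity, read by MTT assay, with a stated time of 96 h (on this read-out lower numbers stand for stronger inhibition and higher numbers for weaker inhibition), as the single measure. Among the measured compounds shown here, compound 2 (`COc1cc(C(=O)c2cn(-c3ccccc3)cc2-c2ccc([N+](=O)[O-])cc2)cc(OC)c1OC`) gives 590 nM and holds the highest number of the three measured so far. Compound 3 (`COc1cccc(-c2cn(-c3ccccc3)cc2C(=O)c2cc(OC)c(OC)c(OC)c2)c1`) gives 180 nM in the same read-out, and compound 1 (`COc1cc(C(=O)c2cn(-c3ccccc3)cc2-c2ccc(N)cc2)cc(OC)c1OC`) gives 9 nM as the lowest number. The change to compound 4 (`COc1cc(C(=O)c2cn(-c3cccc(N)c3)cc2-c2ccc([N+](=O)[O-])cc2)cc(OC)c1OC`) is amino in place of hydrogen on an aromatic carbon, meta to a large group, or phenyl to 3-aminophenyl (amino in place of hydrogen on an aromatic carbon). For the measured compounds named here, no measured step makes this exact change, so the evidence is indirect. Nitro in place of amino gives a 66-fold higher number from compound 1 to compound 2 (1.82 log units; beyond the scatter) and counts as large, but that step acts at a different place and compound 4 keeps the 4-nitrophenyl. Going by the values given here, the two steps to 3-methoxyphenyl are a 20-fold higher number from compound 1 to compound 3 (1.30 log units; beyond the scatter) and a 3.3-fold lower number from compound 2 to compound 3 (0.52 log units; beyond the scatter) and again show compound 1 as the only measured amino compound and the lowest number. On this thin basis a modest step towards a lower number is expected in this assay with real doubt about its size. The estimated change is a 3.9-fold lower number from compound 2 to compound 4 (0.59 log units; beyond the scatter) and remains an expectation. The estimate for compound 4 is 150 nM within an expected range of 25 nM to 700 nM for a single measurement.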

Compound 4, half-maximal inhibitory concentration: 110 nM
The estimate for compound 4 lay 1.4-fold (0.13 log units) above the measured number; the range from low to high includes it.
By their numbers in this assay, from the lowest: compound 1; then compounds 4 and 3 (each within the scatter of the next); then compound 2.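

In this assay, among the compounds shown here, the step to compound 4 gives the first direct reading of amino in place of hydrogen at this position, on an aromatic carbon meta to a large group: a 5.4-fold lower number from compound 2 to compound 4 (0.73 log units; beyond the scatter). The earlier compounds shown here placed amino only in the 4-aminophenyl of compound 1, whereas here phenyl to 3-aminophenyl lowers the number with the 4-nitrophenyl kept, so this second place also responds to the change, though only modestly. No measurement shown here accounts for the size or direction of this step.

As far as these compounds go, compound 1 and compound 4 differ in more than one place, so the two amino placements cannot be ranked against each other, and it remains open whether phenyl to 3-aminophenyl would give a similar step with the 4-aminophenyl in place of the 4-nitrophenyl. From the compounds shown here alone, it also remains open whether the step is specific to amino, as a single substituent at this position cannot separate amino from other groups such as dimethylamino, hydroxyl or a carboxylic acid.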